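Methyl for chloro at two places in the pyrazole acid series

The source may hold more compounds than are shown below. What is called first, only, known or untested is meant among the compounds shown, and "the series" means these compounds.

Compound 1 `Cc1cn(Cc2cc(Br)ccc2OCc2ccccc2)nc1C(=O)O`, compound 2 `O=C(O)c1nn(Cc2cc(Br)ccc2OCc2ccccc2)cc1Cl` and compound 3 `Cc1cc(C(=O)O)nn1Cc1cc(Br)ccc1OCc1cccc(Cl)c1` have been measured in a functional assay on CHO-K1 cells for antagonist activity at prostaglandin E2 receptor EP1 subtype (Homo sapiens), read by FLIPR; a higher number here means a weaker inhibitor, a lower number a stronger inhibitor; compound 4 `Cc1cccc(COc2ccc(Br)cc2Cn2nc(C(=O)O)cc2C)c1` has not. In this assay compound 1 gives 1350 nM and compound 3 gives 427 nM, the lowest of the two numbers, with compound 1 standing higher by a gap beyond the scatter. For compound 2 the value < 2000 nM is a limit of the assay, not a number.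

Compound 1 differs from compound 2 by methyl in place of chloro on an aromatic carbon, and the step that the limit leaves unreadable from compound 2 to compound 1 cannot be sized because of the limit of < 2000 nM in this assay, at which 1 of the 3 values shown sits. Compound 4 differs from compound 3 by methyl in place of chloro on an aromatic carbon. The exchanged groups are the same, but the surroundings are not: in the first case the aromatic carbon belongs to a five-membered aromatic ring with 2 nitrogen, next to the ring atom that bears a carboxy group; in the second it belongs to a six-membered aromatic ring of carbon only, meta to a large group. It is therefore the same kind of change, not the same change. How the core of compound 3 differs from that of compound 2 is not broken down here.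

With no readable measured step for this exchange, the expectation for compound 4 rests on the methyl for chloro exchange being small in heavy-atom count and on compound 3 at 427 nM; the step from a 1.3-fold higher number from compound 3 to compound 4 (0.11 log units; within the scatter) is expected to stay within the scatter. Compound 4 is estimated at 550 nM, between 200 nM and 1500 nM.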

Compound 4, inhibition constant: 525 nM
Compound 4: middle estimate off by 1.0-fold (0.02 log units), on the high side; the measured number falls inside the stated range.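

In this assay, the exchange of 3-chlorobenzyl for 3-methylbenzyl gives a 1.2-fold higher number from compound 3 to compound 4 (0.09 log units; within the scatter), so compound 3 and compound 4 cannot be told apart at this place, on an aromatic carbon of a six-membered aromatic ring of carbon only, meta to a large group. This is a single readable pair on a single core, and it shows that the two groups are interchangeable in this read-out only there, not that the exchange would read the same at another place or on another core. The other instance of methyl in place of chloro, between compound 2 and compound 1, sits on a five-membered aromatic ring and cannot be sized, so carrying the change from one core to another remains untested because compound 2 stands at a limit and not at a number: the limit of < 2000 nM in this assay, at which 1 of the 4 values shown sits.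

The compounds shown leave open how other groups, such as fluoro, methoxy or trifluoromethyl, would read at the place of this exchange on the core of compound 3. They also leave open whether a primary amide in place of the carboxylic acid would keep a readable value on either core.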